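Swapping a dichlorophenyl for a chloronitrophenyl on compound 3

The source may hold more compounds than are shown below. What is called first, only, known or untested is meant among the compounds shown, and "the series" means these compounds.

Compounds measured in a functional assay on PC-3 cells (Homo sapiens) for inhibition, read by MTT assay, with a stated time of 72 h; a lower number here means a stronger inhibitor, a higher number a weaker inhibitor:
compound 1 `O=C(/C=C/c1ccc(Cl)c([N+](=O)[O-])c1)/C=C/c1ccccc1Oc1ncnc2ccc(Cl)cc12` gives 9760 nM
compound 2 `O=C(/C=C/c1ccccc1Oc1ncnc2ccc(Cl)cc12)/C=C/c1cccc(Cl)c1Cl` gives 8350 nM
compound 3 `O=C(/C=C/c1ccc(Oc2ncnc3ccc(Cl)cc23)cc1)/C=C/c1ccc(Cl)c(Cl)c1` gives 18800 nM

Compound 3 stands at the highest of the three numbers. Its gap to compound 1 lies within the scatter of repeated measurements, while its gap to compound 2 lies beyond it, so only against compound 2 can compound 3 be called the weaker inhibitor.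

Compound 4 `O=C(/C=C/c1ccc(Oc2ncnc3ccc(Cl)cc23)cc1)/C=C/c1cc([N+](=O)[O-])ccc1Cl` differs from compound 3 in one place: 2-chloro-5-nitrophenyl in place of 3,4-dichlorophenyl on a double-bonded chain carbon bound to a double-bonded chain carbon. For the measured compounds named here, one measured step bears on this exchange: a 1.2-fold lower number from compound 1 to compound 2 (0.07 log units; within the scatter). There a phenyl ring carrying a chloro and a nitro group gave way to a dichlorophenyl at the same kind of place, on a double-bonded chain carbon bound to a double-bonded chain carbon, and the number barely moved. The step from compound 3 to compound 4 runs the other way, from a dichlorophenyl to a chloronitrophenyl, on a different core. On that single precedent, the expected change in this assay is none beyond the scatter, in either direction, so for compound 4 the estimated step is a 1.2-fold lower number from compound 3 to compound 4 (0.07 log units; within the scatter). Compound 4 is therefore expected to give about 16000 nM, within roughly 7000 nM to 36000 nM.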

Compound 4, half-maximal inhibitory concentration: 3150 nM
Compound 4: the middle estimate sits 5.1-fold (0.71 log units) above what was measured; measured number below the stated range.
By their numbers in this assay, from the lowest: compound 4; then compounds 2, 1 and 3 (each within the scatter of the next, the first and the last beyond it).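

In this assay, this place on the core of compound 3 responds clearly: 2-chloro-5-nitrophenyl in place of 3,4-dichlorophenyl gives a 6.0-fold lower number from compound 3 to compound 4 (0.78 log units; beyond the scatter). The earlier step at the same kind of place, a 1.2-fold lower number from compound 1 to compound 2 (0.07 log units; within the scatter), showed no such change, so an exchange between a chloronitrophenyl and a dichlorophenyl does not carry one outcome from one core to the other, although the rings in the two steps also differ in their substitution. Nothing measured here gives a reason for the lower number of compound 4.

A single exchange cannot separate what the entering nitro group contributes from what the altered arrangement of chloro groups contributes. Going by these compounds, it also remains open whether an amine or a nitrile in place of that nitro group would keep the lower number.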